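The source may report more compounds than this note shows. Statements on the series, on what has been measured and on what is new or still open speak of the compounds shown alone.

The measured compounds:

Compound 1, `O=C(NO)c1ccc(CN(Cc2ccccc2)S(=O)(=O)c2c(F)c(F)c(F)c(F)c2F)cc1`: in an assay on isolated protein for inhibition of histone deacetylase 11 (Homo sapiens), read by mobility shift assay (on this read-out higher numbers stand for weaker inhibition and lower numbers for stronger inhibition), compound 1 gives 122 nM.
Compound 2, `CC(C)(C)c1ccc(CN(Cc2ccc(C(=O)NO)cc2)S(=O)(=O)c2c(F)c(F)c(F)c(F)c2F)cc1`: in this assay compound 2 gives 88 nM.
Compound 3, `O=C(NO)c1ccc(CN(Cc2ccccc2)S(=O)(=O)c2cc(F)c(F)c(F)c2F)cc1`: in this assay compound 3 gives 115 nM.

The three share one core and differ only in the substituents on their aromatic rings. Compound 3 holds the second highest of the three numbers; its nearest neighbour is compound 1 and its furthest is compound 2, and both of those gaps lie within the scatter, so the three cannot be ranked against one another.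

Compound 4, `O=C(NO)c1ccc(CN(Cc2cccc(F)c2)S(=O)(=O)c2cc(F)c(F)c(F)c2F)cc1`, is not yet measured. It differs from compound 3 by fluoro in place of hydrogen on an aromatic carbon.

Among the measured compounds shown here, two measured steps bear on this change. The step of a 1.1-fold lower number from compound 1 to compound 3 (0.03 log units; within the scatter) concerns the other aromatic ring and was within the scatter. The step of a 1.4-fold lower number from compound 1 to compound 2 (0.14 log units; within the scatter) alters the same benzyl ring that is altered here, adding a tert-butyl group, and also stayed within the scatter. Neither step gives any sign that substitution on these rings moves the number in this assay beyond its scatter, so the expected step of a 1.0-fold lower number from compound 3 to compound 4 (0.02 log units; within the scatter) is none beyond the scatter. Compound 4 is therefore estimated at 110 nM, with a range from 60 nM to 210 nM.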

Compound 4, half-maximal inhibitory concentration: 235 nM
For compound 4 the middle estimate is 2.1-fold (0.33 log units) below the measured one, outside the stated range (above it).
By their numbers in this assay, from the lowest: compounds 2, 3, 1 and 4 (each within the scatter of the next, the first and the last beyond it).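

In this assay, fluoro in place of hydrogen on the benzyl ring, meta to a large group, gives a 2.0-fold higher number from compound 3 to compound 4 (0.31 log units; beyond the scatter) and so produces the first step among these compounds that lies beyond the scatter, if only modestly. The earlier steps shown here, a 1.4-fold lower number from compound 1 to compound 2 (0.14 log units; within the scatter) with tert-butyl on this same benzyl ring and a 1.1-fold lower number from compound 1 to compound 3 (0.03 log units; within the scatter) on the other aromatic ring, had both stayed within the scatter and gave no sign that changes on these rings matter in this read-out. This single added fluorine atom shows that the benzyl ring is not indifferent to substitution, and the direction of the step is towards weaker inhibition; no measurement available here accounts for that step.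

The compounds shown leave open whether chloro, methoxy or an amine on this same aromatic carbon would raise the number as fluoro does, or whether the step is particular to fluoro. They also leave open whether the 3-fluorobenzyl change would give a similar step on the core of compound 1, which carries the other fluorinated ring.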